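The compounds below may be only part of what the source reports. "The series", "measured", "known", "first", "only" and "open" are said of these compounds alone.

Measured so far:
compound 1 `CC(C)OC1=C(C(=O)c2ccccc2)C(c2ccc(Br)cc2)N(CCCn2ccnc2)C1=O`: 8720 nM
compound 2 `CCOc1ccc(NC2=C(C(=O)c3ccccc3)C(c3ccc(Br)cc3)N(CCCn3ccnc3)C2=O)cc1`: 20200 nM

Both numbers come from a functional assay on A549 cells (Homo sapiens) for antiproliferative activity, read by MTT assay, with a stated time of 72 h; a lower number here means a stronger inhibitor, a higher number a weaker inhibitor. Going by the values given here, compound 1 stands at the lower of the two numbers; its only neighbour is compound 2, and the step of a 2.3-fold higher number from compound 1 to compound 2 (0.36 log units; beyond the scatter) is modest but beyond the scatter, arising from (4-ethoxyphenyl)amino in place of isopropoxy on a double-bonded ring carbon of the shared core.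

The next compound, compound 3 `O=C(C1=C(Nc2ccc(Cl)cc2)C(=O)N(CCCn2ccnc2)C1c1ccc(Br)cc1)c1ccccc1`, is to be measured in this assay. Its difference from compound 1: (4-chlorophenyl)amino in place of isopropoxy on a double-bonded ring carbon. This is the same kind of exchange as the one already measured, with (4-chlorophenyl)amino rather than (4-ethoxyphenyl)amino entering where isopropoxy leaves, on the same double-bonded ring carbon. Among the compounds with values here, the one measured step that bears on it is a 2.3-fold higher number from compound 1 to compound 2 (0.36 log units; beyond the scatter). Nothing in the two numbers separates a chloro from an ethoxy substituent on the entering ring, so a step of about that size toward a higher number is expected in this assay, estimated as a 1.9-fold higher number from compound 1 to compound 3 (0.29 log units; within the scatter). The number expected for compound 3 is 17000 nM, with a range from 7000 nM to 40000 nM.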

Compound 3, half-maximal inhibitory concentration: 30000 nM
Compound 3: middle estimate off by 1.8-fold (0.25 log units), on the low side; low and high end bracket the measured number.
By their numbers in this assay, from the lowest: compound 1; then compounds 2 and 3 (each within the scatter of the next).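

In this assay the exchange of isopropoxy for a substituted phenylamino group at this double-bonded ring carbon now has a second reading, with a 3.4-fold higher number from compound 1 to compound 3 (0.54 log units; beyond the scatter) for (4-chlorophenyl)amino alongside a 2.3-fold higher number from compound 1 to compound 2 (0.36 log units; beyond the scatter) for (4-ethoxyphenyl)amino, so the direction is the same for both entering groups and compound 1 keeps the lowest number of the three. Chloro in place of ethoxy on the entering aromatic ring gives a 1.5-fold higher number from compound 2 to compound 3 (0.17 log units; within the scatter) and so does not tell the two ring substituents apart in this assay, which ties the step so far to the exchange of isopropoxy for the arylamino group rather than to the substituent it carries. The data at hand give no measured basis for explaining the step from isopropoxy to either amino group.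

In both exchanges the amino nitrogen and the aromatic ring enter together, so their contributions stay unseparated; a phenoxy group or a small alkylamino such as methylamino at this carbon would pull them apart. Going by these compounds, whether any substituent on the entering ring matters also stays open, and plain phenylamino or a ring bearing a carboxylic acid would test that.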